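Phenyl for hydrogen on two cores: toward compound 4

The source may report more compounds than this note shows. Statements on the series, on what has been measured and on what is new or still open speak of the compounds shown alone.

Measured so far:
Compound 1 `CCOC(=O)/C(=C/c1c[nH]c2ccccc12)C(=O)c1ccc([N+](=O)[O-])cc1`; in a functional assay on MT4 cells (Homo sapiens) for antiproliferative activity, read by MTT assay, with a stated time of 96 h (a lower number here means that less compound is needed, a higher number that more compound is needed for the effect), compound 1 gives 100000 nM.
Compound 2 `CCOC(=O)/C(=C/c1c(-c2ccccc2)[nH]c2ccccc12)C(=O)c1ccc([N+](=O)[O-])cc1`; in this assay compound 2 gives 1500 nM.
Compound 3 `N#C/C(=C\c1c[nH]c2ccccc12)S(=O)(=O)c1ccccc1`; in this assay compound 3 is recorded only as the limit > 100000 nM.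

Within the first pair the single change is phenyl in place of hydrogen on an aromatic carbon. It produced a 67-fold lower number from compound 1 to compound 2 (1.82 log units; beyond the scatter), a large step in this assay.

Compound 4 `N#C/C(=C\c1c(-c2ccccc2)[nH]c2ccccc12)S(=O)(=O)c1ccccc1` carries the same change on the core of compound 3: phenyl in place of hydrogen on an aromatic carbon. The two place descriptions agree word for word, so this is the same change, not merely the same kind. How the core of compound 1 and the core of compound 3 differ is not broken down here.

Compound 3 stands at the limit of > 100000 nM in this assay, at which 1 of the 3 values shown sits, so its value is a limit and not a number, and any step from it can only be stated as an expectation.

The expected step is an at least 6.6-fold lower number from compound 3 to compound 4 (0.82 log units; beyond the scatter). This rests on a 67-fold lower number from compound 1 to compound 2 (1.82 log units; beyond the scatter), while allowing that part of the same change may be spent before compound 4 leaves the limit, so a somewhat smaller apparent step is taken as the centre. Going by the values given here, no other pair shows the change, so the expectation leans on one measured step alone.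

The estimate for compound 4 in this assay is 15000 nM, expected to lie between 2500 nM and 100000 nM.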

Compound 4, half-maximal effective concentration: 400 nM
Compound 4: the middle estimate sits 38-fold (1.57 log units) above what was measured; the measured number lies below the stated range.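

In this assay, phenyl in place of hydrogen on an aromatic carbon gives an at least 250-fold lower number from compound 3 to compound 4 (2.39 log units; beyond the scatter), so the direction of the step seen on the core of compound 1 also holds on the core of compound 3. The size of the step does not transfer as a fixed amount, and the two steps stand apart: the same change on two cores in this assay, a 67-fold lower number (1.82 log units; beyond the scatter) from compound 1 to compound 2 and an at least 250-fold lower number (2.39 log units; beyond the scatter) from compound 3 to compound 4, at least 3.7-fold (0.57 log units) apart, beyond the scatter of two such steps. Two cores show a shared direction but give no rule for any further core, and with compound 3 recorded only as a limit, the full size of its step stays unknown: the limit of > 100000 nM in this assay, at which 1 of the 4 values shown sits.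

From the compounds shown here alone, it remains open whether this step is specific to an unsubstituted phenyl or would also appear with a methyl group, or with a phenyl carrying an amine or a carboxylic acid, at the same place on the core. It also remains open which of the parts that separate the core of compound 1 from the core of compound 3 accounts for the gap between the two steps, since the compounds shown do not vary those parts one at a time.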